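The compounds below may be only part of what the source reports. "The series", "measured", "known", "first", "only" and "open" are said of these compounds alone.

Measured so far: compound 1 `COc1ccccc1CNc1nc(N)nc(-c2ccccc2CO)n1` with 3.99, and compound 2 `Nc1nc(NCc2ccc(F)cc2)nc(-c2c(F)cccc2CO)n1` with 4.45.

Compound 2 holds the higher of the two numbers in a functional assay on cells for positive allosteric modulation of G-protein coupled receptor 68 (Homo sapiens), read by a luciferase reporter and cAMP accumulation, with a stated time of 30 min, at pH 6.8 and pH 8.3, in the presence of a further agent that is not named here; a higher number here means a more potent compound, by a factor of ten per unit of this negative logarithm, a lower number a less potent compound. Going by the values given here, its only measured neighbour is compound 1, whose value in this assay lies lower by a margin beyond the usual scatter; the two compounds differ in two places at once, so nothing can be said about what either change alone contributes.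

Compound 3 `COc1ccccc1CNc1nc(N)nc(-c2c(F)cccc2CO)n1` has not yet been measured. It differs from compound 2 in one place: 2-methoxyphenyl in place of 4-fluorophenyl on a saturated chain carbon bound to a nitrogen on an aromatic ring. Compound 3 therefore carries the same group on that chain carbon as compound 1, while keeping the second ring of compound 2.

Among the compounds with values here, because compound 1, the only compound bearing 2-methoxyphenyl at this place, gives 3.99, a modest loss is expected from compound 2 to compound 3 in this assay, of about a number 0.25 log units lower from compound 2 to compound 3 (within the scatter). Compound 3 is estimated at 4.2, within a range from 3.8 to 4.6.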

Compound 3, negative logarithm of the antagonist equilibrium constant: 4.11
The estimate for compound 3 lay 0.09 log units above the measured number, within the range that was stated.
By their numbers in this assay, from the lowest: compounds 1 and 3 (each within the scatter of the next); then compound 2.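

In this assay, the change to 2-methoxyphenyl in place of 4-fluorophenyl on a saturated chain carbon bound to a nitrogen on an aromatic ring gives a number 0.34 log units lower from compound 2 to compound 3 (beyond the scatter) with the rest of the structure held constant, so this place now has a single-change step that the earlier pair could not supply. The other single change, fluoro in place of hydrogen on an aromatic carbon, gives a number 0.12 log units higher from compound 1 to compound 3 (within the scatter) and so does not separate its two compounds in this assay. Of the two differences between compound 1 and compound 2, only the change on the chain carbon has so far given a step beyond the scatter, and no measurement shown offers a reason for either step.

From the compounds shown here alone, the fluoro step has been read only with 2-methoxyphenyl on the chain carbon, so whether it would be the same with 4-fluorophenyl there remains open. Going by these compounds, how a plain phenyl, a cyclohexyl group or a carboxylic acid-bearing phenyl would compare on that chain carbon also remains open.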